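Sulfoxide series: from propyl to 4-chlorobenzyl on the piperazine

The source may report more compounds than this note shows. Statements on the series, on what has been measured and on what is new or still open speak of the compounds shown alone.

Measured compounds:
compound 1, `O=C(CSC(c1ccc(F)cc1)c1ccc(F)cc1)N1CCN(CCCc2ccccc2)CC1`, 28.6 nM
compound 2, `CCCN1CCN(C(=O)C[S+]([O-])C(c2ccc(F)cc2)c2ccc(F)cc2)CC1`, 279 nM

Of the compounds shown here, two have been measured in an assay on membranes from brain (strain Sprague-Dawley) for displacement of a labelled ligand from sodium-dependent dopamine transporter (Rattus norvegicus), read by radioligand binding, with a stated time of 120 min; on this read-out lower numbers stand for stronger inhibition and higher numbers for weaker inhibition. Compound 1 gives 28.6 nM in this assay, and compound 2 gives 279 nM. Compound 2 thus stands at the higher of the two numbers, and its gap to compound 1 lies beyond the scatter. The two compounds differ in more than one place, so no single change can be read from that gap.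

Compound 3, `O=C(C[S+]([O-])C(c1ccc(F)cc1)c1ccc(F)cc1)N1CCN(Cc2ccc(Cl)cc2)CC1`, keeps the sulfoxide and the amide of compound 2 and changes only the group on the piperazine: 4-chlorophenyl in place of ethyl on a saturated chain carbon bound to an amine nitrogen in a ring. Within the data shown here, with no step between measured compounds to lean on, the expectation can only be cautious. Compound 3 is expected to show a moderate step toward a lower number, as a 3.1-fold lower number from compound 2 to compound 3 (0.49 log units; beyond the scatter), with a wide range. The estimate for compound 3 in this assay is 90 nM, with a range from 30 nM to 300 nM.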

Compound 3, inhibition constant: 56.3 nM
Compound 3: the middle estimate sits 1.6-fold (0.20 log units) above what was measured, within the range that was stated.
By their numbers in this assay, from the lowest: compounds 1 and 3 (each within the scatter of the next); then compound 2.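

In this assay, the exchange of propyl for 4-chlorobenzyl on the piperazine gives a 5.0-fold lower number from compound 2 to compound 3 (0.70 log units; beyond the scatter), a modest step. With the sulfoxide and the amide held fixed, this shows that a change at this position alone can move the number beyond the scatter, which the earlier pair could not show, as compound 1 and compound 2 differ in more than one place. No measurement is available that accounts for this step.

The compounds shown leave open whether the step goes with the aromatic ring or with the chlorine, a question that an unsubstituted benzyl group on the same sulfoxide would help to separate. They also leave open how a longer chain, such as 3-phenylpropyl, would read on the sulfoxide.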